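The compounds below may be only part of what the source reports. "The series", "measured", "known", "first", "only" and "open" are said of these compounds alone.

In a functional assay on NCI-H460 cells (Homo sapiens) for cytotoxicity, read by MTT assay, with a stated time of 72 h (on this read-out higher numbers stand for weaker inhibition and lower numbers for stronger inhibition), compound 3 (`CN(C)Cc1ccc2nc(NC(=O)N/N=C/c3c[nH]c4ccccc34)sc2c1`), which has only hydrogen on its aromatic nitrogen, gives 2550 nM. This lies within the scatter of compound 1 (`CN(C)Cc1ccc2nc(NC(=O)N/N=C/c3cn(Cc4ccccc4Cl)c4ccccc34)sc2c1`), which gives 1600 nM. Compound 2 (`CCN(CC)Cc1ccc2nc(NC(=O)N/N=C/c3cn(Cc4ccc(C)cc4)c4ccccc34)sc2c1`) gives 320 nM, a clearly lower number than either of the others.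

Compound 4 (`Cc1ccc(Cn2cc(/C=N/NC(=O)Nc3nc4ccc(CN(C)C)cc4s3)c3ccccc32)cc1`) departs from compound 3 in one place, with 4-methylbenzyl in place of hydrogen on an aromatic nitrogen of the shared core: 4-methylbenzyl in place of hydrogen on an aromatic nitrogen.

Within the data shown here, only one measured step concerns this nitrogen directly, a 1.6-fold higher number from compound 1 to compound 3 (0.20 log units; within the scatter), and it involves 2-chlorobenzyl rather than 4-methylbenzyl. Taken alone, that small step argues against a large shift. Compound 2, with its value of 320 nM, does carry 4-methylbenzyl, but it also differs from compound 4 elsewhere, so it offers only partial guidance. Among the measured compounds shown here, no measured pair isolates the effect of that group.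

Weighing the two, a moderate step towards a lower number is expected in this assay, with a return to the scatter still possible. Compound 4 is estimated at 1000 nM, with an expected range of 350 nM to 2500 nM. The estimated change is a 2.6-fold lower number from compound 3 to compound 4 (0.41 log units; beyond the scatter).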

Compound 4, half-maximal inhibitory concentration: 200 nM
The estimate for compound 4 lay 5.0-fold (0.70 log units) above the measured number, outside the stated range (below it).
By their numbers in this assay, from the lowest: compounds 4 and 2 (each within the scatter of the next); then compounds 1 and 3 (each within the scatter of the next).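

On the aromatic nitrogen of the five-membered ring, a large step now appears in this assay: 4-methylbenzyl in place of hydrogen gives (a 13-fold lower number from compound 3 to compound 4 (1.11 log units; beyond the scatter)), whereas the earlier step at this nitrogen, with 2-chlorobenzyl leaving, stayed small (a 1.6-fold higher number from compound 1 to compound 3 (0.20 log units; within the scatter)), so compound 1 goes against any reading that a benzyl-type group on this nitrogen is enough by itself. What that group carries therefore matters in this set, since 4-methylphenyl in place of 2-chlorophenyl gives (an 8.0-fold lower number from compound 1 to compound 4 (0.90 log units; beyond the scatter)), while dimethylamino in place of diethylamino on the saturated chain carbon stays within the scatter (a 1.6-fold lower number from compound 2 to compound 4 (0.20 log units; within the scatter)), which shows that the value of compound 2 was already tied to the 4-methylbenzyl group rather than to its diethylamino group. Nothing given here offers an explanation for these differences.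

The compounds shown leave open whether the step at this nitrogen belongs to the methyl group, to its place on the ring, or to the absence of chlorine, and a plain benzyl or a 4-methoxybenzyl group would help separate these. They also leave open how a morpholine in place of dimethylamino would fare on the saturated chain carbon.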